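The source may hold more compounds than are shown below. What is called first, only, known or untested is meant among the compounds shown, and "the series" means these compounds.

Measured in a functional assay on A-431 cells (Homo sapiens) for antiproliferative activity, read by CCK-8 assay, with a stated time of 72 h; a lower number here means a stronger inhibitor, a higher number a weaker inhibitor:
- Compound 1 `Cc1cc(Nc2cc(N3CCN(C)CC3)nc(Nc3ccc([N+](=O)[O-])cc3)n2)n[nH]1`: 150 nM
- Compound 2 `Cc1cc(Nc2cc(N3CCN(C)CC3)nc(Nc3ccc(Cl)cc3)n2)n[nH]1`: 162 nM
- Compound 3 `COc1cccc(Nc2nc(Nc3cc(C)[nH]n3)cc(N3CCN(C)CC3)n2)c1`: 332 nM

Compound 3 has the highest number of the three and is the weakest inhibitor of the set, since both steps to it lie beyond the scatter: a 2.2-fold higher number from compound 1 to compound 3 (0.35 log units; beyond the scatter) and a 2.0-fold higher number from compound 2 to compound 3 (0.31 log units; beyond the scatter). The next structure, compound 4 `Cc1cc(Nc2cc(N3CCN(C)CC3)nc(Nc3cccc([N+](=O)[O-])c3)n2)n[nH]1`, has nitro in place of methoxy on an aromatic carbon, so 3-methoxyphenyl becomes 3-nitrophenyl: nitro in place of methoxy on an aromatic carbon.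

The closest evidence is a 2.2-fold higher number from compound 1 to compound 3 (0.35 log units; beyond the scatter), although that step alters both the group and its place on the ring. The step of a 1.1-fold higher number from compound 1 to compound 2 (0.03 log units; within the scatter) lies within the scatter and separates nitro from chloro by nothing measurable. Among the compounds with values here, no measured compound carries 3-nitrophenyl, so the evidence is indirect. In this assay a modest move toward a lower number is therefore expected, and it may not clear the scatter. The estimated step is a 1.4-fold lower number from compound 3 to compound 4 (0.16 log units; within the scatter). Compound 4 is expected at 230 nM, with an estimated range of 110 nM to 480 nM.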

Compound 4, half-maximal inhibitory concentration: 166 nM
Estimate against measurement, compound 4: 1.4-fold (0.14 log units) above; measured number inside the range.
By their numbers in this assay, from the lowest: compounds 1, 2, 4 and 3 (each within the scatter of the next, the first and the last beyond it).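

In this assay, within the data shown here, holding the nitro group fixed and moving it gives a 1.1-fold higher number from compound 1 to compound 4 (0.04 log units; within the scatter) as the step from 4-nitrophenyl to 3-nitrophenyl, the first reading of place alone, and place shows no measurable effect for this group. The exchange of 4-chlorophenyl for 3-nitrophenyl gives a 1.0-fold higher number from compound 2 to compound 4 (0.01 log units; within the scatter) and is equally unresolved, while nitro in place of methoxy on the same aromatic carbon gives a 2.0-fold lower number from compound 3 to compound 4 (0.30 log units; within the scatter) and so cannot be separated from the scatter, even though compound 3 stands apart from compound 1 and compound 2. No measurement offered here explains any of these steps. The compounds shown leave open whether 4-methoxyphenyl would read like compound 3 or like compound 1. They also leave open how an amine or a carboxylic acid would behave on this aromatic carbon.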